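This account rests on a few compounds, and the source may have more. Where it says the series, first, only, none or still open, it means among the compounds named here.

In a functional assay on MCF7 cells (Homo sapiens) for cytotoxicity, read by MTT assay, with a stated time of 72 h (a lower number here means a stronger inhibitor, a higher number a weaker inhibitor), compound 1 `COc1cc(C=C2C(=O)N(c3ccc(Cl)cc3)N(c3ccc(Cl)cc3)C2=O)ccc1O` gives 22800 nM and compound 2 `COc1cccc(C=C2C(=O)N(c3ccc(Cl)cc3)N(c3ccc(Cl)cc3)C2=O)c1` gives 18100 nM. The gap between these two is a 1.3-fold lower number from compound 1 to compound 2 (0.10 log units; within the scatter). Compound 3 `COc1ccc(C=C2C(=O)N(c3ccc(Cl)cc3)N(c3ccc(Cl)cc3)C2=O)cc1OC` is known only as a limit of the assay, > 128000 nM.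

Compound 4 `O=C1C(=Cc2ccc(F)cc2F)C(=O)N(c2ccc(Cl)cc2)N1c1ccc(Cl)cc1` has 2,4-difluorophenyl in place of 3,4-dimethoxyphenyl on a double-bonded chain carbon bound to a double-bonded ring carbon. Among the compounds with values here, no measured step involves fluorine. The nearest guides are the two steps into compound 3, an at least 5.6-fold higher number from compound 1 to compound 3 (0.74 log units; beyond the scatter) and an at least 7.0-fold higher number from compound 2 to compound 3 (0.84 log units; beyond the scatter), which are read here in reverse. Compound 4 no longer carries 3,4-dimethoxyphenyl. The expected change is an at least 5.1-fold lower number from compound 3 to compound 4 (0.70 log units; beyond the scatter), toward a lower number and of about the size of those two steps. For compound 4 the estimate is 25000 nM, with an expected range of 8000 nM to 80000 nM.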

Compound 4, half-maximal inhibitory concentration: 22000 nM
Beside the measured number, compound 4's estimate is 1.1-fold (0.06 log units) above it; the measured number falls inside the stated range.
By their numbers in this assay, from the lowest: compounds 2, 4 and 1 (each within the scatter of the next). At a limit, above all of these: compound 3.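

In this assay 2,4-difluorophenyl on the double-bonded chain carbon stays level with 3-methoxyphenyl (a 1.2-fold higher number from compound 2 to compound 4 (0.08 log units; within the scatter)) and with 4-hydroxy-3-methoxyphenyl (a 1.0-fold lower number from compound 1 to compound 4 (0.02 log units; within the scatter)), so neither methoxy nor hydroxy is needed for a number in this range. Of the groups shown, only 3,4-dimethoxyphenyl stands apart (an at least 5.8-fold lower number from compound 3 to compound 4 (0.76 log units; beyond the scatter)). Compound 3 is known only as a limit, so that step is a bound and not a measured gap: the limit of > 128000 nM in this assay, at which 1 of the 4 values shown sits.

Going by these compounds, how far compound 3 lies past its limit stays open. So does whether an amine or a carboxylic acid on this phenyl ring would hold the same level.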